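This account rests on a few compounds, and the source may have more. Where it says the series, first, only, none or still open, it means among the compounds named here.

Of the compounds shown here, three have so far been measured in a functional assay on A549 cells (Homo sapiens) for cytotoxicity, read by MTT assay, with a stated time of 48 h; on this read-out higher numbers stand for weaker inhibition and lower numbers for stronger inhibition. Compound 1 `CC(C)=CCC/C(C)=C/CC/C(C)=C/CC[C@@H]1[C@@]2(C)CC/C(=N\OCc3cn(-c4ccc(Cl)cc4)nn3)C(C)(C)[C@@H]2CC[C@@]1(C)O` gives 12300 nM in this assay, and compound 2 `CC(C)=CCC/C(C)=C/CC/C(C)=C/CC[C@@H]1[C@@]2(C)CC/C(=N\OCc3cn(-c4cccc(Br)c4)nn3)C(C)(C)[C@@H]2CC[C@@]1(C)O` gives 11700 nM. Compound 3 `COc1cccc(-n2cc(COc3ccc(/C=C4\C[C@]5(C)[C@@H](CC/C=C(\C)CC/C=C(\C)CCC=C(C)C)[C@](C)(O)CC[C@H]5C(C)(C)C4=O)cc3)nn2)c1`, which carries its substituted phenyl in a different arrangement around the shared core, gives 45700 nM in this assay, the highest of the three numbers; its nearest neighbour is compound 1, lower by a gap beyond the scatter, and compound 2 lies further away still.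

Compound 4 `CC(C)=CCC/C(C)=C/CC/C(C)=C/CC[C@@H]1[C@@]2(C)C/C(=C\c3ccc(OCc4cn(-c5cccc([N+](=O)[O-])c5)nn4)cc3)C(=O)C(C)(C)[C@@H]2CC[C@@]1(C)O` is compound 3 with one change: nitro in place of methoxy on an aromatic carbon. Within the data shown here, the only step measured between compounds that differ in one place is a 1.1-fold lower number from compound 1 to compound 2 (0.02 log units; within the scatter), an exchange of one substituent on the phenyl for another that leaves the number within the scatter. It bears on the present change only loosely, as it concerns halogens rather than nitro and methoxy and sits on a differently arranged core. Nothing measured points to a shift beyond the scatter, so the expected step is a 1.0-fold lower number from compound 3 to compound 4 (0.01 log units; within the scatter). Compound 4 is therefore estimated at 45000 nM, with a range from 18000 nM to 110000 nM.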

Compound 4, half-maximal inhibitory concentration: 126000 nM
Beside the measured number, compound 4's estimate is 2.8-fold (0.45 log units) below it, outside the stated range (above it).
By their numbers in this assay, from the lowest: compounds 2 and 1 (each within the scatter of the next); then compound 3; then compound 4.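

In this assay, nitro in place of methoxy on an aromatic carbon, meta to a large group, gives a 2.8-fold higher number from compound 3 to compound 4 (0.44 log units; beyond the scatter) and so moves the number beyond the scatter, towards weaker inhibition. Among these compounds, the only earlier step, a 1.1-fold lower number from compound 1 to compound 2 (0.02 log units; within the scatter) and within the scatter, exchanged a different pair of substituents on a different arrangement around the core, so this is the first sign that a substituent at this place on the phenyl can change the number. No measurement on hand accounts for the size or direction of this step.

An amine or a carboxylic acid at this place could read on either side of compound 3, and the compounds shown do not settle which. They also leave open whether 3-nitrophenyl gives a similar step on the arrangement of compound 1.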